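The source may hold more compounds than are shown below. What is called first, only, known or untested is meant among the compounds shown, and "the series" means these compounds.

Measured compounds:
compound 1, `COc1cc2cc(Oc3ccc(NC(=O)Nc4ccccc4)cc3)c(C)nc2cc1OC`, 42.7%
compound 2, `COc1cc2cc(Oc3ccc(NC(=O)Nc4ccc(C(F)(F)F)cc4)cc3)c(C)nc2cc1OC`, 59.6%

Both compounds were tested in a functional assay on SR cells (Homo sapiens) for inhibition, read by sulforhodamine B assay, with a stated time of 48 h, tested at 10 uM; on this read-out higher numbers stand for a weaker effect at the one concentration tested and lower numbers for a stronger effect. Compound 1 stands at the lower of the two numbers; its nearest neighbour is compound 2, reached by a number 16.9 percentage points higher from compound 1 to compound 2 (beyond the scatter), a change that lies beyond the scatter and is modest in size. Compound 3, `COc1cc2cc(Oc3ccc(NC(=O)Nc4ccc(Cl)c(Cl)c4)cc3)c(C)nc2cc1OC`, has not yet been measured in this assay. It differs from compound 1 in one place: 3,4-dichlorophenyl in place of phenyl on an amide-type nitrogen.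

Within the data shown here, the only measured step that bears on this change is the one from compound 1 to compound 2, where a trifluoromethyl in place of hydrogen on an aromatic carbon raised the number by a modest amount. Among the measured compounds shown here, two chlorine atoms on the same ring are a different substitution, and no measured pair shows the effect of chlorine here. For the measured compounds named here, on the single step available, a move of similar size in the same direction is expected. For compound 3 the expected step is a number 12.3 percentage points higher from compound 1 to compound 3 (beyond the scatter). Compound 3 is therefore estimated at 55%, within a range from 35% to 75%.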

Compound 3, a percentage reported as activity, at one concentration (the size of the read-out at that concentration, not a potency): 18%
The estimate for compound 3 lay 37 percentage points above the measured number, outside the stated range (below it).
By their numbers in this assay, from the lowest: compound 3; then compound 1; then compound 2.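

In this assay, 3,4-dichlorophenyl in place of phenyl on the amide-type nitrogen gives a number 24.7 percentage points lower from compound 1 to compound 3 (beyond the scatter) and thus a stronger effect at the one concentration tested, so a substituted ring at this position need not weaken the effect as the 4-(trifluoromethyl)phenyl of compound 2 does. Set against that group, the same position gives a number 41.6 percentage points lower from compound 2 to compound 3 (beyond the scatter) in the same assay, and compound 1 lies between the two substituted compounds. The direction of change at this position therefore depends on which substituted ring enters, not simply on whether the ring carries a substituent.

The data shown offer no measured basis for explaining the difference between these rings. Going by these compounds, it remains open whether one chlorine alone, as in 4-chlorophenyl or 3-chlorophenyl, would carry the stronger effect, and how a ring bearing a methoxy group, an amine or a carboxylic acid would compare with phenyl, while the reading at a single concentration leaves potency itself undefined.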